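Trading Two Chlorines for a Methoxy Group on the Benzyl Arm

A few compounds are considered here, and "the series" means these few. Any claim that something is new, unique, unknown or untested is made for them only; others in the source may bear on it.

Compound 1 `Nc1cc(N)c2nc(-c3ccccc3)c(NCc3ccc(Cl)c(Cl)c3)nc2c1`: 3470 nM
Compound 2 `CCOC(=O)[C@H](CCC(=O)O)NC(=O)c1ccc(Sc2nc3cc(N)cc(N)c3nc2-c2ccccc2)cc1`: 12600 nM
Compound 3 `Nc1cc(N)c2nc(-c3ccccc3)c(Sc3ccc(Cl)c(Cl)c3)nc2c1`: 21400 nM

Of the compounds shown here, three built on the same core have been tested in a functional assay on SK-MEL-5 cells (Homo sapiens) for inhibition, read by sulforhodamine B assay, with a stated time of 48 h; a higher number here means a weaker inhibitor of growth, a lower number a stronger inhibitor of growth. Compound 1 gives the lowest number of the three. Compound 2 lies beyond the scatter above it, and compound 3 lies further still, so compound 1 stands as the strongest growth inhibitor of this set.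

Compound 4 `COc1ccc(CNc2nc3cc(N)cc(N)c3nc2-c2ccccc2)cc1` has not yet been measured. It differs from compound 1 in a single place: 4-methoxyphenyl in place of 3,4-dichlorophenyl on a saturated chain carbon bound to a nitrogen on an aromatic ring. For the measured compounds named here, no measured pair isolates this change, so nothing in the numbers shows directly how the assay responds to it. The expectation therefore rests on compound 1 alone, which holds the best value in this assay with 3470 nM, and on the general observation that a substitution of this kind more often weakens than strengthens growth inhibition.

Compound 4 is expected to give about 7000 nM in this assay, with a likely range from 2500 nM to 20000 nM. The step of a 2.0-fold higher number from compound 1 to compound 4 (0.30 log units; within the scatter) is thus estimated as a modest move toward weaker growth inhibition, one that may only just exceed the scatter.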

Compound 4, concentration for 50% growth inhibition: 17800 nM
The estimate for compound 4 lay 2.5-fold (0.41 log units) below the measured number, within the range that was stated.
By their numbers in this assay, from the lowest: compound 1; then compounds 2, 4 and 3 (each within the scatter of the next).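

In this assay, for the compounds shown here, the change to 4-methoxyphenyl brings a 5.1-fold higher number from compound 1 to compound 4 (0.71 log units; beyond the scatter), the first step here that isolates a single change, and it shows that growth inhibition responds to what the ring on this arm carries. The response appears even though 3,4-dichlorophenyl and 4-methoxyphenyl have the same count of heavy atoms and the same six-membered aromatic ring of carbon only, so those shared counts alone do not preserve the activity of compound 1. No measurement available here bears on why the number rises, so the step stands as an observation without an explanation.

A single pair also cannot separate the loss of the two chlorines from the arrival of the methoxy group, since both happen in the same step. A plain unsubstituted phenyl ring or a ring carrying a single chlorine would help to divide the step into those two parts, while a hydroxyl group or a carboxylic acid on the ring would show how far the response extends to other kinds of group.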